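Trimming One Ring Carbon From Compound 1

This account rests on a few compounds, and the source may have more. Where it says the series, first, only, none or still open, it means among the compounds named here.

Measured so far in a physicochemical assay for lipophilicity, read by HPLC, measured as chromatographic lipophilicity, at pH 7.4 (a lower number here means a more polar compound, a higher number a more lipophilic compound), are three compounds:
- compound 1 `O=C(C1CCCC1)N1N=CCC1c1ccccc1` gives 5.4
- compound 2 `Cc1nnc(N2CCC(C(=O)N3N=CC[C@H]3c3ccccc3)CC2)o1` gives 3.2
- compound 3 `CC(C)(C)C(=O)N1N=CCC1c1cccc(F)c1` gives 5.9

Of these three numbers, compound 1 has the second highest (5.4). Compound 3 lies a little higher and compound 2 far lower, and both gaps are larger than the usual scatter of repeated measurements.

The next compound to be measured is compound 4 `O=C(C1CCC1)N1N=CCC1c1ccccc1`, which differs from compound 1 in one place: it has cyclobutyl in place of cyclopentyl on a carbonyl carbon. Going by the values given here, no two measured compounds differ in only one place, so the data offer no direct guide to the size of this step, and any forecast is a judgement. In this assay a modest downward move seems likely, with the estimated step (a number 0.40 log units lower from compound 1 to compound 4 (beyond the scatter)) close to the edge of the scatter. Compound 4 is expected at 5 as a middle estimate, with a likely range of 4.7 to 5.3 around it.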

Compound 4, distribution coefficient: 4.7
Beside the measured number, compound 4's estimate is 0.30 log units above it, and the stated range covers the measured number.
By their numbers in this assay, from the lowest: compound 2; then compound 4; then compound 1; then compound 3.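

Going by these compounds alone, this is the first pair here that differs in one place only, so the size of a change at this position can be read directly rather than judged from unrelated compounds. In this assay, cyclobutyl in place of cyclopentyl on a carbonyl carbon gives a number 0.70 log units lower from compound 1 to compound 4 (beyond the scatter) and is a clear change, showing that the loss of a single ring carbon at this position can move the number by more than the usual scatter. No measurement shown gives a reason for the size of this step.

A single pair cannot show whether the number would keep moving in the same direction with cyclopropyl or back with cyclohexyl on the same carbonyl carbon. As far as these compounds go, how an open chain such as n-propyl, or a ring carrying an amine, would compare at this position also remains open.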